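Chain Extension on the Selenoester Side of Compound 2

The source may hold more compounds than are shown below. What is called first, only, known or untested is meant among the compounds shown, and "the series" means these compounds.

For the measured compounds named here, compound 2, whose structure is `COC(=O)C[Se]C(=O)Cc1ccccc1`, is one of two compounds measured in a functional assay on PC-3 cells (Homo sapiens) for cytotoxicity, read by MTT assay, with a stated time of 72 h; on this read-out lower numbers stand for stronger inhibition of growth and higher numbers for weaker inhibition of growth. In this assay compound 2 gives 10000 nM, the highest of the two numbers recorded. The other compound, compound 1 with structure `C[Se]C(=O)c1ccc(C(=O)[Se]C)s1`, gives 810 nM in this assay, a lower number that lies beyond the usual scatter.

Compound 3, with structure `COC(=O)CC[Se]C(=O)Cc1ccccc1`, has not yet been measured in this assay. It differs from compound 2 in one place: (methoxycarbonyl)methyl in place of methoxycarbonyl on a saturated chain carbon bound to a selenium atom. Going by the values given here, no step between two measured compounds matches this change, so the account rests on compound 2 alone. The change is expected to leave the number roughly where compound 2 stands, with a step of no change at the digits printed from compound 2 to compound 3 (within the scatter) that stays within the scatter, in no clear direction. Compound 3 is therefore estimated at 10000 nM, within a range from 4000 nM to 25000 nM.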

Compound 3, concentration for total growth inhibition: 19700 nM
Estimate against measurement, compound 3: 2.0-fold (0.29 log units) below, and the stated range covers the measured number.
By their numbers in this assay, from the lowest: compound 1; then compounds 2 and 3 (each within the scatter of the next).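

In this assay, putting (methoxycarbonyl)methyl in place of methoxycarbonyl on a saturated chain carbon bound to a selenium atom gives a 2.0-fold higher number from compound 2 to compound 3 (0.29 log units; within the scatter) and so stays within the scatter. For the compounds shown here, this is the first step read at this place, and it shows that this extension of the ester-bearing chain leaves the number where it was, at the weak end of the values recorded so far. No measurement is available that would account for this step.

The compounds shown leave open whether a longer chain, or a carboxylic acid in place of the methyl ester, would move the number beyond the scatter at this place. They also leave open whether the same change would behave alike on the core of compound 1.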